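Replacing acetyl(methyl)amino with cyano on a shared core

A few compounds are considered here, and "the series" means these few. Any claim that something is new, unique, unknown or untested is made for them only; others in the source may bear on it.

In a toxicity assay on CCRF-CEM cells (Homo sapiens) for cytotoxicity (a higher number here means that more compound is tolerated, a lower number that less compound is tolerated), compound 1 `COc1cccc2c1nc(-c1c(F)cccc1F)n2Cc1c(F)cccc1F` stands at 44.3 uM and compound 2 `CCc1cccc2c1nc(-c1c(F)cccc1F)n2Cc1c(F)cccc1F` stands at 26.1 uM with ethyl in place of methoxy on an aromatic carbon. That gap is a 1.7-fold lower number from compound 1 to compound 2 (0.23 log units; within the scatter) so the two cannot be told apart.

Compound 3 `CC(=O)N(C)c1cccc2c1nc(-c1c(F)cccc1F)n2Cc1c(F)cccc1F` gives > 100 uM which is a limit of the assay and not a number. The measured steps that reach it are an at least 2.2-fold higher number from compound 1 to compound 3 (0.35 log units; beyond the scatter) and an at least 3.8-fold higher number from compound 2 to compound 3 (0.58 log units; beyond the scatter) and both carry acetyl(methyl)amino onto the shared core.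

Compound 4 `N#Cc1cccc2c1nc(-c1c(F)cccc1F)n2Cc1c(F)cccc1F` differs from compound 3 by cyano in place of acetyl(methyl)amino on an aromatic carbon with cyano in place of acetyl(methyl)amino on an aromatic carbon. Among the compounds with values here, no measured compound here carries cyano, so the expectation rests on those two steps run in reverse, and the number should fall back toward the values of compound 1 and compound 2. The expected change is an at least 2.5-fold lower number from compound 3 to compound 4 (0.39 log units; beyond the scatter) which would be a modest drop of about the same size as those steps. In this assay the estimate for compound 4 is 40 uM with 15 uM and 100 uM as the expected ends of its range.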

Compound 4, half-maximal toxic concentration: 26.7 uM
Compound 4: the middle estimate sits 1.5-fold (0.18 log units) above what was measured, within the range that was stated.
By their numbers in this assay, from the lowest: compounds 2, 4 and 1 (each within the scatter of the next). At a limit, above all of these: compound 3.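

In this assay, putting cyano on this aromatic carbon gives an at least 3.7-fold lower number from compound 3 to compound 4 (0.57 log units; beyond the scatter), so the high number seen with acetyl(methyl)amino does not carry over to this smaller group. Cyano also gives a 1.0-fold higher number from compound 2 to compound 4 (0.01 log units; within the scatter) and a 1.7-fold lower number from compound 1 to compound 4 (0.22 log units; within the scatter), so three different groups at this position, cyano, ethyl and methoxy, cannot be told apart, and among the four compounds only acetyl(methyl)amino stands out. Compound 3 gives > 100 uM, which is a limit of the assay and not a number, and it is alone there: the limit of > 100 uM in this assay, at which 1 of the 4 values shown sits.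

Which part of acetyl(methyl)amino goes with the higher number, the carbonyl or the methyl on nitrogen, stays open. So does whether a dimethylamino group, a carboxylic acid or a longer chain at this position would group with compound 3 or with the other three.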